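Swapping bromo for iodo on one aromatic carbon

This account rests on a few compounds, and the source may have more. Where it says the series, first, only, none or still open, it means among the compounds named here.

In a functional assay on HCC 2998 cells (Homo sapiens) for inhibition, read by sulforhodamine B assay, with a stated time of 48 h (a higher number here means a weaker inhibitor of growth, a lower number a stronger inhibitor of growth), compound 1 (`Cc1ccc(NC(=O)/C=C/c2ccccc2)c(C(N)=O)c1`) gives 6450 nM. Compound 2 (`NC(=O)c1cc(Br)ccc1NC(=O)/C=C/c1ccccc1`) has no number to stand on, since the entry for compound 2 reads "not determined" (no result reported). Compound 3 (`NC(=O)c1cc(I)ccc1NC(=O)/C=C/c1ccccc1`) has yet to be measured. The structural change is iodo in place of bromo on an aromatic carbon. Among the compounds with values here, no measured step shows what such a swap does, so no direction and no step beyond the scatter is expected in this assay. Within the data shown here, the only guide is compound 1 at 6450 nM. Compound 3 is estimated at 5000 nM, with an expected range of 1500 nM to 15000 nM.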

Compound 3, concentration for 50% growth inhibition: 1250 nM
Beside the measured number, compound 3's estimate is 4.0-fold (0.60 log units) above it; the whole stated range lies above it.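

In this assay, iodo in place of methyl on this aromatic carbon brings a 5.2-fold lower number from compound 1 to compound 3 (0.71 log units; beyond the scatter) and so shows that the number responds to the group at this place, with iodo giving the stronger inhibitor of growth of the two. The swap from bromo to iodo itself cannot be read, as compound 2 has no number. Nothing measured here explains the step.

Where bromo falls relative to methyl and iodo remains unknown. So does whether chloro, an amine or a carboxylic acid on this carbon would lower the number further or raise it.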